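Shortening the Chain from Heptyl to Pentyl

This account rests on a few compounds, and the source may have more. Where it says the series, first, only, none or still open, it means among the compounds named here.

In an ADME assay on HeLa cells (Homo sapiens) for cytotoxicity, read by microscopy, with a stated time of 6 days (a higher number here means that more compound is tolerated, a lower number that less compound is tolerated), three close relatives of compound 4 have already been tested. Compound 1 `CCCCCCNc1cncc(C(=O)NCc2ccccc2)n1` carries a hexyl chain on the nitrogen on the aromatic ring; in this assay compound 1 gives > 100000 nM, which is a limit of the assay rather than a number. Compound 2 `CCCCNc1cncc(C(=O)NCc2ccccc2)n1` carries a butyl chain; compound 2 gives > 100000 nM, again a limit. Compound 3 `CCCCCCCNc1cncc(C(=O)NCc2ccccc2)n1` carries a heptyl chain, and compound 3 gives > 100000 nM, also a limit. Because all three sit at the limit of > 100000 nM in this assay, at which 3 of the 3 values shown sit, none of the steps among them can be read: a step that the two limits leave unreadable from compound 1 to compound 2, a step that the two limits leave unreadable from compound 1 to compound 3 and a step that the two limits leave unreadable from compound 2 to compound 3. Compound 4 `CCCCCNc1cncc(C(=O)NCc2ccccc2)n1` is reached from compound 3 by the change (hydrogen in place of ethyl on a saturated chain carbon, five bonds along the chain from a nitrogen on an aromatic ring). The chain of compound 4 is shorter than that of compound 1 and longer than that of compound 2, both of which gave only limits. Among the measured compounds shown here, no step of readable size exists, so no shift beyond the scatter is expected, and the step of a number no higher from compound 3 to compound 4 (the limit leaves the size open) is estimated to be none. Compound 4 is therefore expected to give about 100000 nM, between 50000 nM and 200000 nM, most likely again reported only as a limit.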

Compound 4, minimum cytotoxic concentration: > 100000 nM
Compound 4: only a limit was reported; the forecaster's own chance of this, stated with the estimate: 90%; the middle value sits exactly at the limit.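

In this assay compound 4 gives > 100000 nM as a limit of the assay, not a number. Its steps to compound 1, compound 2 and compound 3 cannot be read, since all four sit at one limit: the limit of > 100000 nM in this assay, at which 4 of the 4 values shown sit. The compounds shown leave open what concentration of any of these chains, from butyl to heptyl, harms the cells, and whether chain length matters here.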